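Ester to Acid: Expected Effect on Dipeptidyl Peptidase 9 Inhibition

The source may report more compounds than this note shows. Statements on the series, on what has been measured and on what is new or still open speak of the compounds shown alone.

Measured compounds:
Compound 1 `CC#CCn1c(N2CCC[C@@H](N)C2)nc2c1c(=O)n(Cc1c(Br)cccc1C(=O)O)c(=O)n2C` gives > 100000 nM in an ADME assay on isolated protein for inhibition of Dipeptidyl peptidase 9 (Homo sapiens), with stated times of 15 min, 60 s and 20 min; a lower number here means a stronger inhibitor, a higher number a weaker inhibitor; this is a limit of the assay.
Compound 2 `CC#CCn1c(N2CCC[C@@H](N)C2)nc2c1c(=O)n(Cc1cccc(F)c1C(=O)O)c(=O)n2C` gives > 100000 nM in this assay; this too is a limit.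
Compound 3 `CC#CCn1c(N2CCC[C@@H](N)C2)nc2c1c(=O)n(Cc1ccc(Br)cc1C(=O)OCC)c(=O)n2C` gives > 100000 nM in this assay; again only a limit.

Compound 3 thus stands where all three measured compounds sit, at the limit of > 100000 nM in this assay, at which 3 of the 3 values shown sit. The three steps among them, a step that the two limits leave unreadable from compound 1 to compound 2, a step that the two limits leave unreadable from compound 1 to compound 3 and a step that the two limits leave unreadable from compound 2 to compound 3, are therefore unreadable: they show no difference that can be sized.

Compound 4 `CC#CCn1c(N2CCC[C@@H](N)C2)nc2c1c(=O)n(Cc1ccc(Br)cc1C(=O)O)c(=O)n2C` differs from compound 3 by hydrogen in place of ethyl on an oxygen next to a carbonyl group. Among the compounds with values here, the two measured acids, compound 1 and compound 2, are free carboxylic acids and sit at the limit just as the ester compound 3 does, so no measured step suggests that this change would bring a readable gain.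

For compound 4 the step that the limit leaves unreadable from compound 3 to compound 4 is expected to be unreadable, with compound 4 again at the limit. The estimate for compound 4 in this assay is 200000 nM, in a range from 100000 nM to 1000000 nM.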

Compound 4, half-maximal inhibitory concentration: > 100000 nM
Compound 4 ended at the assay's limit; the forecaster's own chance of this, stated with the estimate: 90%; the middle value is on the limit's open side.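

In this assay compound 4 gives > 100000 nM as a limit of the assay. Its steps from compound 1, compound 2 and compound 3 therefore cannot be read. The compounds shown leave open how far each lies past this limit, and which change, if any, would bring a readable value.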